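This account rests on a few compounds, and the source may have more. Where it says the series, first, only, none or still open, it means among the compounds named here.

Measured so far in a functional assay on U2OS cells (Homo sapiens) for antiproliferative activity, read by MTT assay, with a stated time of 72 h; on this read-out higher numbers stand for weaker inhibition and lower numbers for stronger inhibition:
compound 1 `CCCCCOC1=C(C(=O)c2ccccc2)C(c2ccc(Br)cc2)N(CCCn2ccnc2)C1=O` gives 9140 nM
compound 2 `O=C(C1=C(Nc2ccc(Cl)cc2)C(=O)N(CCCn2ccnc2)C1c1ccc(Br)cc1)c1ccccc1` gives 22800 nM

Going by the values given here, compound 2 has the higher of these two numbers; the only measured step, a 2.5-fold higher number from compound 1 to compound 2 (0.40 log units; beyond the scatter), separates it from compound 1 and concerns a different part of the shared core. Compound 3 `O=C(C1=C(Nc2ccccc2Br)C(=O)N(CCCn2ccnc2)C1c1ccc(Br)cc1)c1ccccc1` differs from compound 2 by 2-bromophenyl in place of 4-chlorophenyl on an amine nitrogen. Among the compounds with values here, no measured step exchanges one aryl group for another on that nitrogen, so the data give no guide to this change, and the expectation is a step no larger than the scatter, in no settled direction. Compound 3 is therefore expected to give about 22800 nM in this assay, within 9000 nM to 57000 nM. The expected step is no change at the digits printed from compound 2 to compound 3 (within the scatter).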

Compound 3, half-maximal inhibitory concentration: 16900 nM
Beside the measured number, compound 3's estimate is 1.3-fold (0.13 log units) above it; low and high end bracket the measured number.
By their numbers in this assay, from the lowest: compounds 1, 3 and 2 (each within the scatter of the next, the first and the last beyond it).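

In this assay, 2-bromophenyl in place of 4-chlorophenyl on the amine nitrogen gives a 1.3-fold lower number from compound 2 to compound 3 (0.13 log units; within the scatter), so this exchange of aryl groups, which alters both the halogen and its place on the ring, shows no clear effect. Replacing pentyloxy with (2-bromophenyl)amino gives a 1.8-fold higher number from compound 1 to compound 3 (0.27 log units; within the scatter), whereas the (4-chlorophenyl)amino replacement gave a 2.5-fold higher number from compound 1 to compound 2 (0.40 log units; beyond the scatter), so the difference from pentyloxy is not firmly established for both arylamino groups. No available evidence explains these numbers. Still open, going by these compounds, is how 4-bromophenyl or unsubstituted phenyl on that nitrogen would compare, which would separate the halogen's identity from its place.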